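A few compounds are considered here, and "the series" means these few. Any claim that something is new, unique, unknown or untested is made for them only; others in the source may bear on it.

In a functional assay on RS4-11 cells (Homo sapiens) for inhibition, read by CCK-8 assay, with a stated time of 48 h (on this read-out higher numbers stand for weaker inhibition and lower numbers for stronger inhibition), compound 2 `O=C(Nc1cccc([N+](=O)[O-])c1)N1CCN(S(=O)(=O)c2sccc2-c2ccccc2Oc2ccc(O)c(O)c2)CC1` gives 9800 nM and compound 3 `O=[N+]([O-])c1cccc(NC(=S)NCCNS(=O)(=O)c2ccc(-c3ccccc3OCc3ccccc3)s2)c1` gives 11600 nM so these two stand within the scatter of each other. Compound 1 `COc1ccc(Oc2ccccc2-c2ccsc2S(=O)(=O)N2CCN(C(=S)Nc3ccc([N+](=O)[O-])cc3)CC2)cc1OC` reads > 50000 nM as a limit of the assay and not a number. Going by the values given here, compound 2 therefore holds one of only two numeric readings, level with compound 3 within the scatter.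

Compound 4 `COc1ccc(Oc2ccccc2-c2ccsc2S(=O)(=O)N2CCN(C(=O)Nc3cccc([N+](=O)[O-])c3)CC2)cc1OC` departs from compound 2 in one place: 3,4-dimethoxyphenyl in place of 3,4-dihydroxyphenyl on an oxygen on an aromatic ring with 3,4-dimethoxyphenyl in place of 3,4-dihydroxyphenyl on an oxygen on an aromatic ring. Among the compounds with values here, no measured pair isolates this change, so its size in this assay cannot be read directly. Within the data shown here, the one measured compound that also carries the 3,4-dimethoxyphenyl group is compound 1, whose > 50000 nM is again a limit. That single reading is thin support, but it leans toward a higher number and so toward weaker inhibition. The estimated step of a 2.2-fold higher number from compound 2 to compound 4 (0.35 log units; beyond the scatter) is expected to be moderate in size and to point in that direction, although a result within the scatter remains possible, as does a reading that ends as a limit. For compound 4 the expected value is 22000 nM with an estimated range of 9000 nM to 50000 nM in this series.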

Compound 4, half-maximal inhibitory concentration: > 50000 nM
Compound 4 ended at the assay's limit; the forecaster's own chance of this, stated with the estimate: 30%; at least 2.2-fold (0.35 log units) between middle value and limit.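

In this assay, the change from 3,4-dihydroxyphenyl to 3,4-dimethoxyphenyl on an oxygen on an aromatic ring now has a measured pair, with an at least 5.1-fold higher number from compound 2 to compound 4 (0.70 log units; beyond the scatter), so at this position the two free hydroxyl groups of compound 2 go with stronger inhibition than the two methoxy groups of compound 4. Compound 4 gives > 50000 nM, a limit of the assay and not a number, so the step sets only a floor on the size of this change. The step from compound 1 to compound 4 cannot be read, and the exchange it carries stays without a size: the limit of > 50000 nM in this assay, at which 2 of the 4 values shown sit.

Still open, as far as these compounds go, is whether both hydroxyl groups are needed, which a phenyl carrying a single hydroxyl, or one hydroxyl with one methoxy, would settle, and whether an amine or a carboxylic acid on that ring could stand in for them. Going by these compounds alone, also open is how far the change reaches beyond this core, since the only other numeric reading belongs to compound 3, which differs from compound 2 in more than one place.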